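Swapping Chloro for Fluoro on a Shared Core

A few compounds are considered here, and "the series" means these few. Any claim that something is new, unique, unknown or untested is made for them only; others in the source may bear on it.

Of the compounds shown here, three have been measured in a functional assay on Raji cells (Homo sapiens) for cytotoxicity, read by MTT assay, with a stated time of 48 h; on this read-out lower numbers stand for stronger inhibition and higher numbers for weaker inhibition. Compound 1 `Cc1ccc(Cn2c(/C=C3\SC(=S)N(CC(=O)O)C3=O)nc3ccc(Cl)cc32)cc1` gives 2790 nM, and compound 2 `Cc1ccc(Cn2c(/C=C3\SC(=S)N(CC(=O)O)C3=O)nc3ccc(F)cc32)cc1` gives 2440 nM. The change between them is fluoro in place of chloro on an aromatic carbon, and it produced a 1.1-fold lower number from compound 1 to compound 2 (0.06 log units; within the scatter). Compound 3 `O=C(O)CN1C(=O)/C(=C/c2nc3ccc(Cl)cc3n2Cc2ccccc2F)SC1=S` gives 8870 nM; it differs from compound 1 by 2-fluorophenyl in place of 4-methylphenyl on a saturated chain carbon bound to an aromatic nitrogen, which gave a 3.2-fold higher number from compound 1 to compound 3 (0.50 log units; beyond the scatter).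

Compound 4 `O=C(O)CN1C(=O)/C(=C/c2nc3ccc(F)cc3n2Cc2ccccc2F)SC1=S` is not yet measured. It differs from compound 3 by fluoro in place of chloro on an aromatic carbon, the same change as that from compound 1 to compound 2, made at the same place. Because the earlier step was a 1.1-fold lower number from compound 1 to compound 2 (0.06 log units; within the scatter), the expected step in this assay is a 1.1-fold lower number from compound 3 to compound 4 (0.06 log units; within the scatter), a change that should stay within the scatter. Compound 4 is therefore estimated at 7800 nM, with a plausible range from 4000 nM to 16000 nM.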

Compound 4, half-maximal inhibitory concentration: 22400 nM
Estimate against measurement, compound 4: 2.9-fold (0.46 log units) below; measured number outside the range, above it.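

In this assay, fluoro in place of chloro on an aromatic carbon gave a 2.5-fold higher number from compound 3 to compound 4 (0.40 log units; beyond the scatter), so the step seen on the core of compound 1 did not carry over to the core of compound 3: the same change on two cores in this assay, a 1.1-fold lower number (0.06 log units; within the scatter) from compound 1 to compound 2 and a 2.5-fold higher number (0.40 log units; beyond the scatter) from compound 3 to compound 4, 2.9-fold (0.46 log units) apart, beyond the scatter of two such steps. Read the other way, 2-fluorophenyl in place of 4-methylphenyl gave a 9.2-fold higher number from compound 2 to compound 4 (0.96 log units; beyond the scatter), a larger step than the one between the two chloro compounds: the same change on two cores in this assay, a 3.2-fold higher number (0.50 log units; beyond the scatter) from compound 1 to compound 3 and a 9.2-fold higher number (0.96 log units; beyond the scatter) from compound 2 to compound 4, 2.9-fold (0.46 log units) apart, beyond the scatter of two such steps. These four compounds show that the two changes do not add independently, but they do not show why, and one pair on each core cannot show how general this is.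

The compounds shown leave open how bromo or methoxy would behave on the same aromatic carbon. They also leave open whether unsubstituted phenyl on the saturated chain carbon would follow the 4-methylphenyl or the 2-fluorophenyl compounds.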